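Swapping Methyl for Chloro on a Receptor Agonist

The compounds below may be only part of what the source reports. "The series", "measured", "known", "first", "only" and "open" are said of these compounds alone.

Compound 3 `Cc1ccccc1-c1ccc(N(C[C@@H](N)CC(C)C)C(=O)[C@@H]2C[C@H]2c2ccccc2)cc1` was tested in a functional assay for agonist activity at G protein-coupled receptor 88 (Homo sapiens), read by HTRF and cAMP accumulation (on this read-out lower numbers stand for an effect already at smaller amounts and higher numbers for an effect only at larger amounts of compound), and gives 3400 nM. Among the three measured compounds this is the second highest number: compound 1 `CC[C@H](C)[C@H](N)CN(C(=O)[C@@H]1C[C@H]1c1ccc(Cl)cc1)c1ccc(-c2ccccc2)cc1` gives 4300 nM, within the scatter of compound 3, while compound 2 `CC(C)C[C@H](N)CN(C(=O)[C@@H]1C[C@H]1c1ccccc1)c1ccc(C2=CCCC2)cc1` gives 1200 nM, and a 2.8-fold higher number from compound 2 to compound 3 (0.45 log units; beyond the scatter). Compound 4 `CC(C)C[C@H](N)CN(C(=O)[C@@H]1C[C@H]1c1ccccc1)c1ccc(-c2ccccc2Cl)cc1` differs from compound 3 in one place: chloro in place of methyl on an aromatic carbon. Among the measured compounds shown here, no measured step shows this exchange; the one measured step, cyclopent-1-en-1-yl to 2-methylphenyl, is a different change, and compound 1 carries its chloro on another ring. With nothing that bears on it, no step beyond the scatter is expected, so no change at the digits printed from compound 3 to compound 4 (within the scatter) is the estimate. Compound 4 is therefore expected to give 3400 nM, in a range from 1400 nM to 8500 nM.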

Compound 4, half-maximal effective concentration: 3800 nM
Compound 4: the middle estimate sits 1.1-fold (0.05 log units) below what was measured; the range from low to high includes it.
By their numbers in this assay, from the lowest: compound 2; then compounds 3, 4 and 1 (each within the scatter of the next).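

On an aromatic carbon ortho to a large group, methyl and chloro cannot be told apart in this assay, which shows a 1.1-fold higher number from compound 3 to compound 4 (0.05 log units; within the scatter) for this exchange. The 2-chlorophenyl group in place of cyclopent-1-en-1-yl gives a 3.2-fold higher number from compound 2 to compound 4 (0.50 log units; beyond the scatter) and so, like 2-methylphenyl with a 2.8-fold higher number from compound 2 to compound 3 (0.45 log units; beyond the scatter), lies beyond the scatter. Nothing available gives a reason for either result.

On these data alone, whether fluoro, methoxy or an amine at this place would match methyl and chloro stays open. So does whether this match holds on any other core.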